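Methyl for hydrogen on the saturated ring, second instance

The compounds below may be only part of what the source reports. "The series", "measured", "known", "first", "only" and "open" are said of these compounds alone.

The three measured compounds share one read-out, a functional assay on U-87MG ATCC cells (Homo sapiens) for inhibition, read by MTT assay, with a stated time of 72 h; on this read-out lower numbers stand for stronger inhibition and higher numbers for weaker inhibition. Compound 1 `COc1cc2c(Oc3ccc(NC(=O)c4nn(-c5ccccc5C)c(=O)cc4C)cc3F)ccnc2cc1OCCCN1CCCCC1` gives 2500 nM. Compound 2 `COc1cc2c(Oc3ccc(NC(=O)c4nn(-c5ccccc5C)c(=O)cc4C)cc3F)ccnc2cc1OCCCN1CCC(C)CC1` carries methyl in place of hydrogen on a saturated ring carbon; in this assay compound 2 gives 2240 nM, and the step is a 1.1-fold lower number from compound 1 to compound 2 (0.05 log units; within the scatter). Compound 3 `COc1ccc(-n2nc(C(=O)Nc3ccc(Oc4ccnc5cc(OCCCN6CCCCC6)c(OC)cc45)c(F)c3)c(C)cc2=O)cc1` differs from compound 1 in its core by 4-methoxyphenyl in place of 2-methylphenyl on an aromatic nitrogen; in this assay compound 3 gives 1800 nM, a step of a 1.4-fold lower number from compound 1 to compound 3 (0.14 log units; within the scatter). All three numbers sit within the usual scatter of one another, so no ordering among them is drawn.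

Compound 4 `COc1ccc(-n2nc(C(=O)Nc3ccc(Oc4ccnc5cc(OCCCN6CCC(C)CC6)c(OC)cc45)c(F)c3)c(C)cc2=O)cc1` has not been measured. It differs from compound 3 by methyl in place of hydrogen on a saturated ring carbon, the same change as that from compound 1 to compound 2, at the same place on a saturated ring carbon, here on the core of compound 3. For the measured compounds named here, only one earlier instance exists, so the expectation rests on that single step: because a 1.1-fold lower number from compound 1 to compound 2 (0.05 log units; within the scatter) lay within the scatter, the step in this assay is expected to be a 1.1-fold lower number from compound 3 to compound 4 (0.04 log units; within the scatter). Compound 4 is estimated at 1650 nM in this assay, with a likely range from 850 nM to 3300 nM.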

Compound 4, half-maximal inhibitory concentration: 2840 nM
Compound 4: middle estimate off by 1.7-fold (0.24 log units), on the low side; measured number inside the range.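

In this assay, methyl in place of hydrogen on the saturated ring carbon gives a 1.6-fold higher number from compound 3 to compound 4 (0.20 log units; within the scatter), and this step does not differ from the earlier one on the other core: the same change on two cores in this assay, a 1.1-fold lower number (0.05 log units; within the scatter) from compound 1 to compound 2 and a 1.6-fold higher number (0.20 log units; within the scatter) from compound 3 to compound 4, 1.8-fold (0.25 log units) apart, within the scatter of two such steps

Likewise, 4-methoxyphenyl in place of 2-methylphenyl on the aromatic nitrogen gives a 1.3-fold higher number from compound 2 to compound 4 (0.10 log units; within the scatter), again in line with its earlier instance: the same change on two cores in this assay, a 1.4-fold lower number (0.14 log units; within the scatter) from compound 1 to compound 3 and a 1.3-fold higher number (0.10 log units; within the scatter) from compound 2 to compound 4, 1.8-fold (0.25 log units) apart, within the scatter of two such steps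

Across these two cores, then, neither change yields a step beyond the scatter and neither depends measurably on the core, but this does not establish that either change has a real effect on the read-out, nor does it predict the outcome on any further core.

The compounds shown leave open whether any change at this end of the molecule moves the number beyond the scatter. A hydroxyl or a larger alkyl group on the piperidine, a morpholine or piperazine in its place, or a longer chain to the ring nitrogen would each test this.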